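A few compounds are considered here, and "the series" means these few. Any claim that something is new, unique, unknown or untested is made for them only; others in the source may bear on it.

Measured so far in an ADME assay on NCM460 cells (Homo sapiens) for cytotoxicity, read by CCK-8 assay, with a stated time of 48 h; on this read-out lower numbers stand for stronger inhibition and higher numbers for weaker inhibition:

- compound 1 `COc1ccc(/C=C\c2cc(OC)c(OC)c(OC)c2)cc1OCc1ccc(CN[C@H](C(=O)O)[C@H](C)O)cc1` gives > 50000 nM, a limit of the assay rather than a number.
- compound 2 `COc1ccc(/C=C\c2cc(OC)c(OC)c(OC)c2)cc1OCc1ccc(CN2CC(C(=O)O)C2)cc1` gives > 50000 nM, also a limit of the assay.
- compound 3 `COc1ccc(/C=C\c2cc(OC)c(OC)c(OC)c2)cc1OCc1ccc(CN2CC[C@@H](O)C2)cc1` gives 53000 nM.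

Compound 1 therefore stands at a limit in this assay and cannot be placed more exactly than that. Two of the three values shown sit at the limit of > 50000 nM in this assay, at which 2 of the 3 values shown sit, and the third, for compound 3, lies close to it. Because of this the three measured steps cannot be read in size: a step that the two limits leave unreadable from compound 1 to compound 2, a step that the limit leaves unreadable from compound 1 to compound 3 and a step that the limit leaves unreadable from compound 2 to compound 3 all leave only the impression that exchanging the group on the saturated chain carbon bound to an aromatic carbon has not moved any compound into a clearly measurable range.

Compound 4 `COc1ccc(/C=C\c2cc(OC)c(OC)c(OC)c2)cc1OCc1ccc(CN2CCCCC2C(=O)NCCN)cc1` is the next member of the series. Compared with compound 1 the change is 2-((2-aminoethyl)carbamoyl)piperidin-1-yl in place of (1-carboxy-2-hydroxypropyl)amino on a saturated chain carbon bound to an aromatic carbon. None of the three measured steps can be read, so no numerical guide to the size of the change exists; the weak cytotoxicity shared by compound 1, compound 2 and compound 3 is the only anchor, and it points to no step beyond the scatter. Compound 4 is therefore estimated at 45000 nM, within 15000 nM to 100000 nM, which would mean an expected step of an at least 1.1-fold lower number from compound 1 to compound 4 (0.04 log units; that floor lies within the scatter).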

Compound 4, half-maximal inhibitory concentration: > 50000 nM
Compound 4: no number, only a limit; the forecaster's own chance of this, stated with the estimate: 50%; middle value at least 1.1-fold (0.04 log units) from the limit.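

In this assay compound 4 gives > 50000 nM, which is a limit of the assay and not a number. Its steps from compound 1, compound 2 and compound 3 therefore cannot be read in size, because the values crowd at one limit: the limit of > 50000 nM in this assay, at which 3 of the 4 values shown sit.

The compounds shown leave open whether any group on this saturated chain carbon bound to an aromatic carbon would give a cytotoxicity clearly inside the measurable range.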